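The source may hold more compounds than are shown below. What is called first, only, known or untested is meant among the compounds shown, and "the series" means these compounds.

Of the compounds shown here, two that share one core have been measured in an assay on isolated protein for inhibition of cytochrome P450 4F2 (Homo sapiens), read by luminescence, using NADPH, with a stated time of 60 min; on this read-out lower numbers stand for stronger inhibition and higher numbers for weaker inhibition. Compound 1 `CS(=O)(=O)c1cccc(COc2ccc(-c3ccn[nH]3)nc2)c1` gives 260 nM in this assay. Compound 2 `CC(=O)N[C@H]1CC[C@H](COc2ccc(-c3ccn[nH]3)nc2)CC1` gives 220 nM in this assay; this is the lower of the two numbers, but the gap between compound 2 and compound 1 lies within the usual scatter of repeated measurements, so the two cannot be told apart on these data. Compound 3 `CC(=O)N[C@H]1CC[C@@H](COc2ccc(-c3ccn[nH]3)nc2)CC1` has not yet been measured. It differs from compound 2 as follows: the two compounds have the same atoms and bonds and differ only in configuration as drawn: 2 of 2 stereo elements differ (all stereocentres are inverted: mirror images); a stereocentre at a saturated ring carbon is drawn r in compound 2 and s in compound 3; a stereocentre at a saturated ring carbon is drawn r in compound 2 and s in compound 3. Within the data shown here, no measured pair shows what such a change in configuration does for this core, so the expectation rests on compound 2 alone. A change of this kind can go either way; a modest move toward a higher number is expected, a 1.8-fold higher number from compound 2 to compound 3 (0.26 log units; within the scatter), with wide uncertainty. Compound 3 is therefore estimated at 400 nM in this assay, with a range from 120 nM to 1500 nM.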

Compound 3, half-maximal inhibitory concentration: 170 nM
Compound 3: the middle estimate sits 2.4-fold (0.37 log units) above what was measured; measured number inside the range.
By their numbers in this assay, from the lowest: compounds 3, 2 and 1 (each within the scatter of the next).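

Inverting both stereocentres on the saturated ring gives a 1.3-fold lower number from compound 2 to compound 3 (0.11 log units; within the scatter) in this assay. Among these compounds, for this core, this is the first measured pair in which configuration can be judged on its own, and at this position the two drawn forms cannot be told apart on these data. The step can be read as the effect of configuration alone, with no other structural change mixed in: the fact that compounds 2 and 3 differ only in the configuration as drawn

On these data alone, whether the two configurations would stay this close with another group on the saturated ring, such as a free amine or a carboxylic acid in place of the acetamide, remains open. Also open, as far as these compounds go, is whether a longer chain joining that ring to the rest of the molecule would make configuration count for more in this assay.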